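A few compounds are considered here, and "the series" means these few. Any claim that something is new, unique, unknown or untested is made for them only; others in the source may bear on it.

Of the compounds shown here, two have so far been measured in a functional assay on HCT-116 cells (Homo sapiens) for inhibition, read by MTT assay, with a stated time of 48 h; on this read-out higher numbers stand for weaker inhibition and lower numbers for stronger inhibition. There compound 1 (`C/C=C/C(=O)N(Cc1ccc(OC)c(N)c1)c1cc(OC)c(OC)c(OC)c1`) gives 300 nM and compound 2 (`COc1ccc(CN(C(=O)CCCCCl)c2cc(OC)c(OC)c(OC)c2)cc1O`) gives 220 nM in the same test. Among the measured compounds shown here, these two values lie within the usual scatter of each other, so compound 1 stands level with the only other measured compound and the two cannot be ranked.

Compound 3 (`C/C=C/C(=O)N(Cc1ccc(OC)c(Cl)c1)c1cc(OC)c(OC)c(OC)c1`), still awaiting measurement, keeps the core of compound 1 and alters a single group: chloro in place of amino on an aromatic carbon, so that 3-amino-4-methoxyphenyl becomes 3-chloro-4-methoxyphenyl. For the measured compounds named here, no measured pair isolates this swap, so any expectation is loose and rests on the structural change alone. In this assay a modest step toward a higher number and weaker inhibition is expected, although a result within the scatter of compound 1 remains possible. The estimate amounts to a 2.3-fold higher number from compound 1 to compound 3 (0.37 log units; beyond the scatter) on this read-out. For compound 3 the expected half-maximal inhibitory concentration is 700 nM with an estimated range from 150 nM to 3000 nM across repeated measurements.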

Compound 3, half-maximal inhibitory concentration: 1420 nM
Estimate against measurement, compound 3: 2.0-fold (0.31 log units) below; measured number inside the range.
By their numbers in this assay, from the lowest: compounds 2 and 1 (each within the scatter of the next); then compound 3.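

In this assay, the position on the aromatic ring ortho to a methoxy group proves sensitive to the group it carries: with the rest of compound 1 kept, chloro in place of amino gives a 4.7-fold higher number from compound 1 to compound 3 (0.68 log units; beyond the scatter) and so moves the number beyond the scatter, though the step is modest in size. Among the compounds shown here, this is the only single-place comparison available so far, and it places 3-amino-4-methoxyphenyl ahead of 3-chloro-4-methoxyphenyl for inhibition in this setting. The change replaces a group counted with a hydrogen-bond donor and acceptor by one counted with neither, but no measurement at hand connects that difference, or any other feature of the swap, to the weaker inhibition.

As far as these compounds go, one swap at one position cannot show whether amino is specifically favoured here, so it remains open whether hydroxy, fluoro, methyl or dimethylamino at this place would give a number nearer that of the amino or the chloro compound. For the compounds shown here, it is also open whether the same exchange would give a similar step with the acyl group of compound 2 in place of the one shared by the pair.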